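A few compounds are considered here, and "the series" means these few. Any claim that something is new, unique, unknown or untested is made for them only; others in the source may bear on it.

Compound 1 `Oc1ccc(-c2cc(-c3cccs3)cc(-c3ccccc3O)n2)cc1` carries a 2-hydroxyphenyl group on its core. In a functional assay on HCT-15 cells (Homo sapiens) for cytotoxicity, read by CCK-8 assay (on this read-out lower numbers stand for stronger inhibition and higher numbers for weaker inhibition), compound 1 gives only a limit, > 50000 nM. Compound 2 `Oc1ccc(-c2cc(-c3cccs3)cc(-c3cccc(O)c3)n2)cc1` has the same atoms joined differently, with 3-hydroxyphenyl in place of 2-hydroxyphenyl on an aromatic carbon. In this assay compound 2 gives 1770 nM. The resulting step is an at least 28-fold lower number from compound 1 to compound 2 (1.45 log units; beyond the scatter); it starts from the limit of > 50000 nM in this assay, at which 2 of the 3 values shown sit, so its true size is not known. Compound 3 `Oc1ccccc1-c1cc(-c2ccccn2)cc(-c2ccccc2O)n1` has a different core; the difference between the two cores is not broken down here. In this assay compound 3 gives only a limit, > 50000 nM. Compound 4 `Oc1cccc(-c2cc(-c3ccccn3)cc(-c3ccccc3O)n2)c1` is not yet measured; it differs from compound 3 by 3-hydroxyphenyl in place of 2-hydroxyphenyl on an aromatic carbon. This is the same kind of change as the earlier one, though here the place is meta to a 2-hydroxyphenyl group and meta to a pyridin-2-yl group, whereas before it was meta to a 4-hydroxyphenyl group and meta to a thiophen-2-yl group. Resting on the earlier step of an at least 28-fold lower number from compound 1 to compound 2 (1.45 log units; beyond the scatter), compound 4 is expected to show an at least 16-fold lower number from compound 3 to compound 4 (1.22 log units; beyond the scatter). Since compound 3 sits at the limit of > 50000 nM in this assay, at which 2 of the 3 values shown sit, the starting point itself is uncertain. Compound 4 is therefore estimated at 3000 nM, in a range from 800 nM to 20000 nM.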

Compound 4, half-maximal inhibitory concentration: > 50000 nM
Compound 4 was reported as a limit; the forecaster's own chance of this, stated with the estimate: 25%; middle value at least 16-fold (1.22 log units) away from the limit.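

Compound 3 and compound 4 are both reported only as limits in this assay, so the step between them cannot be read: the limit of > 50000 nM in this assay, at which 3 of the 4 values shown sit.

The compounds shown leave open whether 3-hydroxyphenyl in place of 2-hydroxyphenyl changes the number at all on the core of compound 3, as the true values of both compounds remain unknown.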